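The compounds below may be only part of what the source reports. "The series", "measured", "known", "first", "only" and "open" are said of these compounds alone.

Measured in an ADME assay on cells (Fibroblast, Homo sapiens) for cytotoxicity, with a stated time of 48 h; a higher number here means a weaker inhibitor, a lower number a stronger inhibitor
Compound 1 `N#Cc1ccc(-c2cncc(-c3cc4ccc(O)cc4[nH]3)c2)cc1` gives 25000 nM
Compound 2 `CS(=O)(=O)c1ccc(-c2cncc(-c3cc4ccc(O)cc4[nH]3)c2)cc1` gives 3000 nM
Compound 3 `Oc1ccc(-c2cncc(-c3cc4ccc(O)cc4[nH]3)n2)cc1` gives 20000 nM

Compound 3 (20000 nM) lies within the usual scatter of compound 1 (25000 nM), and both numbers stand clearly above compound 2 (3000 nM). Compound 4 `N#Cc1ccc(-c2cncc(-c3cc4ccc(O)cc4[nH]3)n2)cc1` differs from compound 3 in one group: cyano in place of hydroxy on an aromatic carbon. Among the measured compounds shown here, no measured step makes this exact swap. The nearest one (an 8.3-fold lower number from compound 1 to compound 2 (0.92 log units; beyond the scatter)) shows that a change at this place can move the number, but it does not involve hydroxy. Compound 1 (25000 nM) carries the same cyano group on a different core, so no step beyond the scatter is expected in this assay here. The expected step is small (a 1.1-fold higher number from compound 3 to compound 4 (0.04 log units; within the scatter)). Compound 4 is estimated at 22000 nM with an expected range from 8000 nM to 50000 nM for the measurement.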

Compound 4, half-maximal inhibitory concentration: 25000 nM
Compound 4: the middle estimate sits 1.1-fold (0.06 log units) below what was measured, within the range that was stated.
By their numbers in this assay, from the lowest: compound 2; then compounds 3, 1 and 4 (each within the scatter of the next).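

Replacing hydroxy with cyano on this aromatic carbon, 4-hydroxyphenyl to 4-cyanophenyl, gives (a 1.3-fold higher number from compound 3 to compound 4 (0.10 log units; within the scatter)) in this assay. The earlier step at this place involved no hydroxy; here, on the core shared by compound 3 and compound 4, a group with a hydrogen-bond donor and one without give numbers within the scatter of each other. Nothing measured here offers an explanation for this.

From the compounds shown here alone, whether methylsulfonyl, which gave (an 8.3-fold lower number from compound 1 to compound 2 (0.92 log units; beyond the scatter)) on the other core, would move the number on this core remains open. So does the outcome for an amine or a carboxylic acid at this place.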